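Chloro to methyl on a well-tolerated compound

This account rests on a few compounds, and the source may have more. Where it says the series, first, only, none or still open, it means among the compounds named here.

Measured in a toxicity assay on THP-1 cells (Homo sapiens) for inhibition; a higher number here means that more compound is tolerated, a lower number that less compound is tolerated:
Compound 1 `COc1ccc(-c2cnc(NC(=O)c3cccnc3)n2C)cc1`: > 100000 nM
Compound 2 `COc1ccc(-c2cnc(NC(=O)c3cccc(Cl)c3)n2C)cc1`: > 28000 nM

Compound 2 stands at > 28000 nM, which is a limit of the assay and not a number. Compound 1 stands at > 100000 nM, which is also a limit.

Compound 3 `COc1ccc(-c2cnc(NC(=O)c3cccc(C)c3)n2C)cc1` differs from compound 2 in one place, with methyl in place of chloro on an aromatic carbon. For the measured compounds named here, the only measured step is a step that the two limits leave unreadable from compound 1 to compound 2. It involves a different change and gives no size to carry over, so no direction can be drawn from it. In this assay, no step beyond the usual scatter is expected, and another limit is quite likely. The expected change is a step that the limit leaves unreadable from compound 2 to compound 3. For compound 3 the estimate is 50000 nM, with an expected range of 25000 nM to 100000 nM.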

Compound 3, half-maximal cytotoxic concentration: > 100000 nM
Compound 3 was reported as a limit; the forecaster's own chance of this, stated with the estimate: 75%; middle value at least 2.0-fold (0.30 log units) from the limit.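

For the compounds shown here, compound 1, compound 2 and compound 3 are all reported only as limits in this assay, so no step between them can be read. The compounds shown leave open how much of each is actually tolerated, and whether methyl in place of chloro changes that at all.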